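This account rests on a few compounds, and the source may have more. Where it says the series, first, only, none or still open, it means among the compounds named here.

In a functional assay on A549 cells (Homo sapiens) for antiproliferative activity, read by MTT assay, with a stated time of 48 h (a higher number here means a weaker inhibitor, a lower number a stronger inhibitor), compound 1 `COc1cccc(-c2nc3cccc(-c4cc(OC)c(OC)c(OC)c4)c3o2)c1` gives 3500 nM and compound 2 `COc1ccc(-c2nc3cccc(-c4cc(OC)c(OC)c(OC)c4)c3o2)cc1OC` gives 2800 nM on the same core. Compound 3 `COc1cc(-c2cccc3nc(-c4ccc(Cl)cc4)oc23)cc(OC)c1OC` gives 5600 nM and lies within the scatter of both. Compound 4 `COc1cc(-c2cccc3nc(-c4ccc5cc[nH]c5c4)oc23)cc(OC)c1OC` carries 1H-indol-6-yl in place of 4-chlorophenyl, and the change is 1H-indol-6-yl in place of 4-chlorophenyl on an aromatic carbon in full. Two measured steps alter the group at this same place: a 1.6-fold higher number from compound 1 to compound 3 (0.20 log units; within the scatter) and a 2.0-fold higher number from compound 2 to compound 3 (0.30 log units; within the scatter) both stay within the scatter, as does a 1.3-fold lower number from compound 1 to compound 2 (0.10 log units; within the scatter) on that group. Within the data shown here, no 1H-indol-6-yl compound has been measured, so no step beyond the scatter is expected in this assay. The estimated size is a 1.9-fold lower number from compound 3 to compound 4 (0.27 log units; within the scatter) and it stays inside that scatter. Compound 4 is expected at 3000 nM (800 nM to 8000 nM as the estimated range).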

Compound 4, half-maximal inhibitory concentration: 55 nM
Beside the measured number, compound 4's estimate is 55-fold (1.74 log units) above it, outside the stated range (below it).
By their numbers in this assay, from the lowest: compound 4; then compounds 2, 1 and 3 (each within the scatter of the next).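

Across 3-methoxyphenyl, 3,4-dimethoxyphenyl and 4-chlorophenyl, the steps at this position stayed within the scatter in this assay and gave no sign that the group here could matter much. 1H-indol-6-yl shows that it can, with a 100-fold lower number from compound 3 to compound 4 (2.01 log units; beyond the scatter) and a 51-fold lower number from compound 2 to compound 4 (1.71 log units; beyond the scatter) and a 64-fold lower number from compound 1 to compound 4 (1.80 log units; beyond the scatter) all beyond the scatter. The compounds shown leave open whether this depends on the indole hydrogen or on the fused ring system, which 1-methyl-1H-indol-6-yl or naphthalen-2-yl at the same place would separate. Nothing available here bears on the reason for this drop.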